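Shifting a Methoxy Group on a Weak Antiproliferative Compound

A few compounds are considered here, and "the series" means these few. Any claim that something is new, unique, unknown or untested is made for them only; others in the source may bear on it.

Compound 1 `COc1cccc(N2C(=O)COc3ccc(-c4cccc(NS(=O)(=O)c5ccc(F)cc5)c4)cc32)c1` gives > 40000 nM in a functional assay on HCT-116 cells (Homo sapiens) for antiproliferative activity, read by MTT assay, with a stated time of 72 h (a higher number here means a weaker inhibitor, a lower number a stronger inhibitor), which is a limit of the assay and not a number. Compound 2 `Cc1ccc(N2C(=O)COc3ccc(-c4cnc5ccccc5c4)cc32)cc1` gives > 40000 nM, also a limit. Compound 3 `Cc1ccc(N2C(=O)COc3ccc(-c4cnc(Cl)c(NS(=O)(=O)c5ccc(F)cc5)c4)cc32)cc1` gives a true number, 34300 nM. Compound 1 therefore stands at the limit of > 40000 nM in this assay, at which 2 of the 3 values shown sit. Compound 4 `COc1ccc(N2C(=O)COc3ccc(-c4cccc(NS(=O)(=O)c5ccc(F)cc5)c4)cc32)cc1` has the same atoms joined differently, with 4-methoxyphenyl in place of 3-methoxyphenyl on an amide-type nitrogen in a ring. Within the data shown here, no measured pair here shows what such a change does. Resting on compound 1 and its limit of > 40000 nM, the expectation in this assay is no step beyond the scatter, an estimated a number no higher from compound 1 to compound 4 (the limit leaves the size open). For compound 4 the estimated value is 40000 nM, with an expected range of 20000 nM to 80000 nM.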

Compound 4, half-maximal inhibitory concentration: 28300 nM
For compound 4 the middle estimate is 1.4-fold (0.15 log units) above the measured one, and the stated range covers the measured number.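

In this assay, 4-methoxyphenyl in place of 3-methoxyphenyl gives an at least 1.4-fold lower number from compound 1 to compound 4 (0.15 log units; that floor lies within the scatter), the only step shown for this position, on an amide-type nitrogen in a ring. Compound 4 gives a true number, 28300 nM, so the change can now be tied to a measured value on one side. The real size of the step stays unknown because compound 1 holds only a limit: the limit of > 40000 nM in this assay, at which 2 of the 4 values shown sit.

The compounds shown leave open how an amine or a carboxylic acid on this phenyl ring would read. From the compounds shown here alone, whether ethoxy, a longer chain, in place of methoxy would move the number beyond the scatter is also open.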